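The source may report more compounds than this note shows. Statements on the series, on what has been measured and on what is new or still open speak of the compounds shown alone.

Measured compounds in a functional assay on K562 cells (Homo sapiens) for antiproliferative activity, read by MTT assay, with a stated time of 72 h; on this read-out higher numbers stand for weaker inhibition and lower numbers for stronger inhibition:
- compound 1 `O=C(O)CN1C(=O)/C(=C/C2=Cc3ccccc3OC2)SC1=S`: > 100000 nM, a limit of the assay
- compound 2 `O=C(O)CN1C(=O)/C(=C/C2=Cc3cc(Br)ccc3OC2)SC1=S`: > 25000 nM, a limit of the assay

Compound 2 stands at a limit only, (the limit of > 25000 nM in this assay, at which 1 of the 2 values shown sits). For compound 1 the value is also a limit, (the limit of > 100000 nM in this assay, at which 1 of the 2 values shown sits). Within the data shown here, the single measured step, a step that the two limits leave unreadable from compound 1 to compound 2, therefore cannot be read in size or direction.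

Compound 3 `CC1Oc2ccc(Br)cc2C=C1/C=C1\SC(=S)N(CC(=O)O)C1=O` differs from compound 2 by methyl in place of hydrogen on a saturated ring carbon. Among the measured compounds shown here, no measured step concerns a change of this kind, and the only step in this assay, a step that the two limits leave unreadable from compound 1 to compound 2, gives no size to lean on. The expectation for this assay is accordingly no step beyond the scatter and, most likely, another limit rather than a number. Compound 3 is expected at 40000 nM, within 10000 nM to 200000 nM. This estimate means a step that the limit leaves unreadable from compound 2 to compound 3, which is not expected to exceed the scatter.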

Compound 3, half-maximal inhibitory concentration: > 50000 nM
Compound 3 gave a limit, no number (the forecaster's own chance of this, stated with the estimate: 75%); middle value at least 1.2-fold (0.09 log units) away from the limit.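

In this assay compound 3 gives > 50000 nM, a limit of the assay and not a number. Among these compounds, compound 2 also stands at a limit, so no step between compound 2 and compound 3 can be read. The compounds shown leave open what size of effect, if any, the bromo or methyl change has.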